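This account rests on a few compounds, and the source may have more. Where it says the series, first, only, none or still open, it means among the compounds named here.

Compound 2 `O=C(COc1ccc(/C=C2\SC(=O)NC2=O)cc1)Nc1ncc([N+](=O)[O-])s1` gives in a functional assay on MCF7 cells (Homo sapiens) for cytotoxicity, read by sulforhodamine B assay, with a stated time of 48 h (a higher number here means a weaker inhibitor of growth, a lower number a stronger inhibitor of growth), only a limit, < 100000 nM. Compound 1 `Cc1cnc(NC(=O)COc2ccc(/C=C3\SC(=O)NC3=O)cc2)s1` also gives only a limit, < 100000 nM. Within the data shown here, the single measured step, a step that the two limits leave unreadable from compound 1 to compound 2, is therefore unreadable in size, and both measured values rest on (the limit of < 100000 nM in this assay, at which 2 of the 2 values shown sit). Compound 3 `O=C(COc1ccc(/C=C2\SC(=O)NC2=O)cc1)Nc1ccccn1` differs from compound 2 by pyridin-2-yl in place of 5-nitro-1,3-thiazol-2-yl on an amide-type nitrogen. Among the measured compounds shown here, no measured step bears on this change, so nothing indicates a shift beyond the usual scatter. Compound 3 is expected to fall near 40000 nM, within 8000 nM to 150000 nM, most likely again reported only as a limit. The expected step is a step that the limit leaves unreadable from compound 2 to compound 3.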

Compound 3, concentration for total growth inhibition: < 100000 nM
Compound 3 gave a limit, no number; the forecaster's own chance of this, stated with the estimate: 70%; the middle value lies beyond the limit too.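

Among these compounds, with compound 3 also giving only a limit, no step among compound 1, compound 2 and compound 3 can be read: the limit of < 100000 nM in this assay, at which 3 of the 3 values shown sit. The compounds shown leave open what number lies behind each limit, and so whether changing the group on the amide-type nitrogen alters growth inhibition at all.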